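A few compounds are considered here, and "the series" means these few. Any claim that something is new, unique, unknown or untested is made for them only; others in the source may bear on it.

Measured compounds in a functional assay on HepG2 cells (Homo sapiens) for antiproliferative activity, with a stated time of 72 h; a lower number here means that less compound is needed, a higher number that more compound is needed for the effect:
- compound 1, `COC(=O)c1cc(=O)c2c(OC)cc(OC)cc2[nH]1`: > 34400 nM
- compound 2, `COC(=O)c1cc(=O)c2c(OC)cc(OC)cc2n1S(=O)(=O)c1ccc(C)cc1`: > 20000 nM
- compound 3, `COc1ccc(-c2cc(=O)c3c(OC)cc(OC)cc3n2S(=O)(=O)c2ccc(C=O)cc2)cc1`: > 34400 nM

Each of these three values is a limit of the assay and not a number. The value of compound 1 is a limit. The value of compound 2 is a limit. The value of compound 3 is a limit as well, so compound 3 stands at the limit of > 34400 nM in this assay, at which 2 of the 3 values shown sit, and nothing in the series places it above or below the other two. Within the data shown here, no step between measured compounds that differ in one place is available here, so no measured step size is known in this assay, and the three limits cannot be ordered against each other.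

Compound 4, `COc1ccc(-c2cc(=O)c3c(OC)cc(OC)cc3n2S(=O)(=O)c2ccc(OC)cc2)cc1`, is not yet measured. It differs from compound 3 in one place: methoxy in place of formyl on an aromatic carbon

Among the measured compounds shown here, with compound 3 sitting at the limit of > 34400 nM in this assay, at which 2 of the 3 values shown sit, and no measured step to lean on, the step of a number no higher from compound 3 to compound 4 (the limit leaves the size open) is expected to be none beyond the scatter. Compound 4 is therefore expected to remain at the limit, with an estimate of 34400 nM and a range from 8000 nM to 100000 nM, the most likely outcome being that this assay again reports only a limit and no number.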

Compound 4, half-maximal effective concentration: > 82700 nM
Compound 4 ended at the assay's limit; the forecaster's own chance of this, stated with the estimate: 85%; at least 2.4-fold (0.38 log units) between middle value and limit.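

In this assay, compound 3 and compound 4 both sit at limits of the assay and not at numbers, so no step can be read between them for methoxy in place of formyl. The compounds shown leave open whether this exchange changes activity at all, and whether any compound of the series reaches a measurable value in this assay.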